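Amide aryl swap at the limit of activity

A few compounds are considered here, and "the series" means these few. Any claim that something is new, unique, unknown or untested is made for them only; others in the source may bear on it.

Compound 1 `Cc1cccc(C(=O)Nc2cccc(-c3oc4cc(-c5ccc(F)cc5)ccc4c(=O)c3O)c2)c1` carries a 3-methylphenyl on the amide carbonyl, and in a functional assay on HepG2 cells (Homo sapiens) for antiproliferative activity, read by CCK-8 assay, with a stated time of 72 h (a lower number here means a stronger inhibitor, a higher number a weaker inhibitor), compound 1 gives 13500 nM. Compound 2 `O=C(Nc1cccc(-c2oc3cc(-c4ccc(F)cc4)ccc3c(=O)c2O)c1)c1ccc(Br)cc1F` is the 4-bromo-2-fluorophenyl analogue. In this assay compound 2 returns only a limit, > 100000 nM, so for compound 2 no number is known. That this is a limit is noted separately (the limit of > 100000 nM in this assay, at which 1 of the 2 values shown sits). For the measured compounds named here, the single measured step, an at least 7.4-fold higher number from compound 1 to compound 2 (0.86 log units; beyond the scatter), is the only guide. Compound 3 `O=C(Nc1cccc(-c2oc3cc(-c4ccc(F)cc4)ccc3c(=O)c2O)c1)c1cnc(Cl)nc1Cl` differs from compound 2 in that (2,4-dichloropyrimidin-5-yl in place of 4-bromo-2-fluorophenyl on a carbonyl carbon). Going by the values given here, no measured step covers an exchange of this kind; the one step at hand shows only that the 3-methylphenyl to 4-bromo-2-fluorophenyl exchange gave a weaker inhibitor. The expected step is an at least 1.2-fold lower number from compound 2 to compound 3 (0.09 log units; that floor lies within the scatter), and compound 3 is expected to stay near the limit. For compound 3 the estimate in this assay is 80000 nM, within 20000 nM to 300000 nM, with a fair chance that only a limit is reported again.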

Compound 3, half-maximal inhibitory concentration: > 100000 nM
Compound 3: no number, only a limit (the forecaster's own chance of this, stated with the estimate: 60%); at least 1.2-fold (0.09 log units) between middle value and limit.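

The 2,4-dichloropyrimidin-5-yl group on the carbonyl carbon, with its two ring nitrogens, does not restore a measurable value in this assay, and the step between compound 2 and compound 3 cannot be read, as both values are limits. Taken from the 3-methylphenyl amide, this exchange gives an at least 7.4-fold higher number from compound 1 to compound 3 (0.86 log units; beyond the scatter), so a second, quite different halogenated aromatic ring also falls on the weak side of that amide. Only compound 1 carries a number, which leaves no ranking among the halogenated rings: the limit of > 100000 nM in this assay, at which 2 of the 3 values shown sit.

Whether the loss follows the halogens or the removal of the 3-methylphenyl group stays open, as the compounds shown do not separate the two. Also open, from the compounds shown here alone, is where a plain phenyl or a piperidine on the carbonyl carbon would fall.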